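Swapping Fluoro for Methoxy on a Shared Core

The source may report more compounds than this note shows. Statements on the series, on what has been measured and on what is new or still open speak of the compounds shown alone.

Of the compounds shown here, three of one family have been tested in an ADME assay on NIH3T3 cells (Mus musculus) for cytotoxicity, read by MTT assay, with a stated time of 24 h; on this read-out higher numbers stand for weaker inhibition and lower numbers for stronger inhibition. Compound 1 `Cc1nnc(SCC(=O)N/N=c2/scc(-c3ccc([N+](=O)[O-])cc3)n2-c2ccccc2)s1` gives 177 ug/mL. Compound 2 `COc1ccc(-c2cs/c(=N/NC(=O)CSc3nncn3C)n2-c2ccccc2)cc1`, which carries a methoxy group and also differs from the others in a second part of the molecule, gives 167 ug/mL. Compound 3 `Cc1nnc(SCC(=O)N/N=c2/scc(-c3ccc(F)cc3)n2-c2ccccc2)s1` gives 383 ug/mL, the highest of the three numbers; its nearest neighbour is compound 1 and its furthest is compound 2, and both gaps lie beyond the usual scatter. Within the data shown here, the one step between compounds that differ in a single place is a 2.2-fold higher number from compound 1 to compound 3 (0.34 log units; beyond the scatter).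

Compound 4 `COc1ccc(-c2cs/c(=N/NC(=O)CSc3nnc(C)s3)n2-c2ccccc2)cc1` has not yet been measured. It differs from compound 3 in one place: methoxy in place of fluoro on an aromatic carbon. Among the measured compounds shown here, no measured step covers this particular exchange, so nothing points strongly in either direction. For the measured compounds named here, the nitro-to-fluoro step was modest, and compound 2, the only measured compound bearing a methoxy group, gives 167 ug/mL. Going by the values given here, the values so far span only a narrow band. Compound 4 is therefore expected to give 230 ug/mL, within a range of 120 ug/mL to 450 ug/mL. The expected step is a 1.7-fold lower number from compound 3 to compound 4 (0.22 log units; within the scatter), close to the edge of the scatter.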

Compound 4, half-maximal inhibitory concentration: 300 ug/mL
Compound 4: middle estimate off by 1.3-fold (0.12 log units), on the low side; low and high end bracket the measured number.
By their numbers in this assay, from the lowest: compounds 2, 1, 4 and 3 (each within the scatter of the next, the first and the last beyond it).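

Fluoro and methoxy on this aromatic carbon, para to a large group, cannot be told apart in this assay here, with a 1.3-fold lower number from compound 3 to compound 4 (0.11 log units; within the scatter) as the step between them. Nitro at the same place now looks less distinct: the exchange for fluoro gives a 2.2-fold higher number from compound 1 to compound 3 (0.34 log units; beyond the scatter) and lies beyond the scatter, while the exchange for methoxy gives a 1.7-fold higher number from compound 1 to compound 4 (0.23 log units; within the scatter) and lies within it, so compound 1 stands clearly apart from only one of the two. Among these compounds, the result also gives the first reading at the other changed place, where 5-methyl-1,3,4-thiadiazol-2-yl in place of 4-methyl-4H-1,2,4-triazol-3-yl on a sulfur gives a 1.8-fold higher number from compound 2 to compound 4 (0.25 log units; within the scatter) and likewise stays within the scatter.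

Going by these compounds, whether an amine, a carboxylic acid or a plain hydrogen at this aromatic carbon would move the number clearly away from these compounds remains open, as does whether any exchange on the sulfur would do so. Nothing available here gives a cause for any of these steps.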